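Swapping the ethyl for fluoro in a nitrile-alkyne mGluR5 ligand

The source may hold more compounds than are shown below. What is called first, only, known or untested is meant among the compounds shown, and "the series" means these compounds.

Compound 1 `CCc1cccc(C#Cc2cccc(C#N)c2)n1` is the stronger of the two measured compounds: in an assay on membranes from brain (strain Sprague-Dawley) for displacement of a labelled ligand from metabotropic glutamate receptor 5 (Rattus norvegicus), read by scintillation counting, with a stated time of 60 min (a lower number here means a stronger inhibitor, a higher number a weaker inhibitor), compound 1 gives 3.4 nM, while compound 2 `CC(=O)c1cccc(C#Cc2cc(F)cc(C#N)c2)n1` gives 64 nM, a gap that is clearly beyond the scatter. Among the measured compounds shown here, no pair of measured compounds differs in a single place, so no measured single step is available as a guide. The new compound 3 `N#Cc1cccc(C#Cc2cccc(F)n2)c1` differs from compound 1 in one respect: fluoro in place of ethyl on an aromatic carbon. The ethyl group that leaves is replaced by a single fluorine atom on the same aromatic carbon of the shared core. For the measured compounds named here, since the only measured change in this set, from compound 1 to compound 2, alters two places at once and loses potency, the expected outcome for compound 3 is a weaker binder, with the step of an 8.8-fold higher number from compound 1 to compound 3 (0.95 log units; beyond the scatter) estimated as a modest loss. Compound 3 is expected to give 30 nM, in the range 6 nM to 200 nM.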

Compound 3, inhibition constant: 150 nM
The estimate for compound 3 lay 5.0-fold (0.70 log units) below the measured number, within the range that was stated.
By their numbers in this assay, from the lowest: compound 1; then compound 2; then compound 3.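

Among the compounds shown here, this is the first change in the set made in one place only, so it isolates the group on the aromatic carbon next to the ring nitrogen. In this assay, fluoro in place of ethyl gives a large loss of binding strength (a 44-fold higher number from compound 1 to compound 3 (1.64 log units; beyond the scatter)), which shows that what sits at this place strongly affects binding and that a single fluorine atom is a poor substitute for the ethyl group in this series. No measurement shown here accounts for the size of this loss.

Still open, on these data alone, is how binding would respond to other groups at this place, such as a methyl, a propyl chain, a chlorine atom or an amine. It is also unclear whether the same swap would cost as much on a core carrying other substituents.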